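A few compounds are considered here, and "the series" means these few. Any claim that something is new, unique, unknown or untested is made for them only; others in the source may bear on it.

Measured so far:
- compound 1, `O=S(=O)(NCCNCc1cccc2ccccc12)c1cc(C(F)(F)F)cc(C(F)(F)F)c1`: 21000 nM
- compound 2, `O=S(=O)(NCCNCc1ccc(-c2ccccc2)cc1)c1cc(C(F)(F)F)cc(C(F)(F)F)c1`: 2400 nM
- compound 3, `O=S(=O)(NCCCNCc1ccc(Cl)c(C(F)(F)F)c1)c1cc(C(F)(F)F)cc(C(F)(F)F)c1`: 9100 nM

All three were run in a functional assay on Capan-2 cells (Homo sapiens) for inhibition, read by MTT assay, with a stated time of 72 h; on this read-out higher numbers stand for weaker inhibition of growth and lower numbers for stronger inhibition of growth. Compound 3 gives 9100 nM, the second highest number of the three: its nearest neighbour is compound 1 with 21000 nM, a higher number beyond the scatter, and its furthest is compound 2 with 2400 nM, a lower number beyond the scatter. Compound 2 thus stands apart with the strongest growth inhibition among these three.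

The next compound, compound 4, `O=S(=O)(NCCCNCc1ccccc1)c1cc(C(F)(F)F)cc(C(F)(F)F)c1`, keeps the three-carbon chain of compound 3 and differs in one place: phenyl in place of 4-chloro-3-(trifluoromethyl)phenyl on a saturated chain carbon bound to an amine nitrogen. Within the data shown here, no measured pair in this set matches that change, so its size cannot be read off directly. Within the set, the benzyl carrying no further group is absent; the bare phenyl is expected to hold growth inhibition near or somewhat below that of compound 3, a step of a 1.6-fold higher number from compound 3 to compound 4 (0.22 log units; within the scatter) that may not exceed the scatter. Compound 4 is therefore estimated at 15000 nM, in the range 5000 nM to 45000 nM.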

Compound 4, concentration for 50% growth inhibition: 14000 nM
The estimate for compound 4 lay 1.1-fold (0.03 log units) above the measured number; measured number inside the range.
By their numbers in this assay, from the lowest: compound 2; then compounds 3, 4 and 1 (each within the scatter of the next, the first and the last beyond it).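

In this assay, among these compounds, the first single-place step, phenyl in place of 4-chloro-3-(trifluoromethyl)phenyl on a saturated chain carbon bound to an amine nitrogen, gives a 1.5-fold higher number from compound 3 to compound 4 (0.19 log units; within the scatter). On the chain shared by these two compounds, the chloro and trifluoromethyl groups taken together are therefore not shown to matter for growth inhibition, and the bare phenyl serves about as well at this place. No measurement at hand gives a reason for the size of this step.

The two groups are lost together here, so a phenyl carrying only the chloro or only the trifluoromethyl would be needed to separate them, and a methoxy or a carboxylic acid on that ring is a further open case. Among the compounds shown here, no pair yet isolates the chain length, so it remains open whether the biphenyl group of compound 2 would hold its standing on the longer chain of compound 4.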